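Orexin-1 antagonist series: cyclopropylmethyl to methoxymethyl on the core

The source may hold more compounds than are shown below. What is called first, only, known or untested is meant among the compounds shown, and "the series" means these compounds.

Measured so far:
- Compound 1 `CNC(=O)[C@@H](c1ccccc1)N1CCn2c(CC3CC3)nc(Cl)c2[C@@H]1CCc1ccc(C(F)(F)F)cc1`: 1430 nM
- Compound 2 `CCc1nc(C(F)(F)F)c2n1CCN([C@@H](C(=O)NC)c1ccccc1)[C@H]2CCc1ccc(C(F)(F)F)cc1`: 1070 nM

Both compounds were run in a functional assay on CHO cells for antagonist activity at Orexin/Hypocretin receptor type 1 (Homo sapiens), read by FLIPR and calcium flux; a lower number here means a stronger inhibitor, a higher number a weaker inhibitor. Compound 1 gives 1430 nM and carries the highest number of the two; the nearest is compound 2, whose value in this assay is 1070 nM, a gap that stays within the usual scatter, so the two cannot be ranked against each other. Among the measured compounds shown here, no pair of measured compounds differs in a single place, so no step size between measured compounds is available to lean on.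

Compound 3 `CNC(=O)[C@@H](c1ccccc1)N1CCn2c(COC)nc(Cl)c2[C@@H]1CCc1ccc(C(F)(F)F)cc1` is the new entry. Relative to compound 1 the change is methoxy in place of cyclopropyl on a saturated chain carbon bound to an aromatic carbon. The change is small in heavy-atom count and sits on a saturated chain carbon bound to an aromatic carbon, away from the trifluoromethyl-bearing side chain and the amide. With no measured step of this kind in the series, the step from compound 1 to compound 3 is expected to be a 1.0-fold higher number from compound 1 to compound 3 (0.02 log units; within the scatter), most likely no change beyond the scatter in either direction. Compound 3 is therefore estimated at 1500 nM, with a range from 500 nM to 4500 nM.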

Compound 3, half-maximal inhibitory concentration: 1650 nM
The estimate for compound 3 lay 1.1-fold (0.04 log units) below the measured number, and the stated range covers the measured number.
By their numbers in this assay, from the lowest: compounds 2, 1 and 3 (each within the scatter of the next).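

In this assay, among the compounds shown here, methoxy in place of cyclopropyl on a saturated chain carbon bound to an aromatic carbon gives a 1.2-fold higher number from compound 1 to compound 3 (0.06 log units; within the scatter) and so offers the first single-place reading at this position; cyclopropylmethyl and methoxymethyl cannot be told apart there. The exchange takes out a three-membered carbon ring and brings in a hydrogen-bond acceptor, and neither difference in the structures is matched by a separable difference in the read-out of this pair. No measurement in hand bears on why the two groups read alike, so the pair gives a description of this position and no explanation of it.

Still open, on these data alone, is how an amine, a carboxylic acid or a longer alkyl chain at this place would read in this assay against these two groups, since cyclopropylmethyl and methoxymethyl alone span only a narrow set of substituents. For the compounds shown here, also open is whether the same exchange would read alike on a core carrying trifluoromethyl in place of the chlorine of compound 1, as no single-place pair on such a core stands in this set.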